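A few compounds are considered here, and "the series" means these few. Any claim that something is new, unique, unknown or untested is made for them only; others in the source may bear on it.

Measured in a functional assay on SMMC-7721 cells (Homo sapiens) for cytotoxicity, read by MTT assay, with a stated time of 24 h; on this read-out lower numbers stand for stronger inhibition and higher numbers for weaker inhibition:
- Compound 1 `CN1C/C(=C\c2ccncc2)C(=O)/C(=C/c2ccccc2F)C1`: 7000 nM
- Compound 2 `O=C1/C(=C/c2cccnc2)CN(S(=O)(=O)c2ccccc2)C/C1=C\c1ccccc1F`: 19100 nM
- Compound 3 `O=C1/C(=C/c2ccncc2)CNC/C1=C\c1ccccc1F`: 18400 nM

Compound 3 lies within the usual scatter of compound 2 and clearly above compound 1, so it sits in the weaker part of this small set. Compound 4 `O=C1/C(=C/c2ccncc2)CN(S(=O)(=O)c2ccccc2)C/C1=C\c1ccccc1F` replaces the hydrogen on the ring amine nitrogen of compound 3 with phenylsulfonyl: phenylsulfonyl in place of hydrogen on an amine nitrogen in a ring.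

Among the compounds with values here, only one measured step changes this nitrogen. That step, a 2.6-fold higher number from compound 1 to compound 3 (0.42 log units; beyond the scatter), is modest and involves a much smaller group, so it gives only a loose guide. A closer hint comes from compound 2, which also carries phenylsulfonyl and gives 19100 nM.

Little change is therefore expected in this assay. The expected step is a 1.2-fold lower number from compound 3 to compound 4 (0.06 log units; within the scatter), which stays within the scatter. Compound 4 is estimated at 16000 nM, with an expected range of 6500 nM to 35000 nM.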

Compound 4, half-maximal inhibitory concentration: 17500 nM
Compound 4: middle estimate off by 1.1-fold (0.04 log units), on the low side; measured number inside the range.
By their numbers in this assay, from the lowest: compound 1; then compounds 4, 3 and 2 (each within the scatter of the next).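

In this assay, the much larger phenylsulfonyl and bare hydrogen on the ring nitrogen give matching numbers (a 1.1-fold lower number from compound 3 to compound 4 (0.02 log units; within the scatter)). With phenylsulfonyl in place, pyridin-4-yl and pyridin-3-yl also match (a 1.1-fold lower number from compound 2 to compound 4 (0.04 log units; within the scatter)), while methyl on this nitrogen stands apart (a 2.5-fold higher number from compound 1 to compound 4 (0.40 log units; beyond the scatter)). No measurement shown explains these results.

From the compounds shown here alone, it remains open how an acetyl group or a longer alkyl chain on this nitrogen would compare. Going by these compounds, it is also open whether the gap to methyl holds with pyridin-3-yl on the double-bonded chain carbon.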